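A few compounds are considered here, and "the series" means these few. Any claim that something is new, unique, unknown or untested is made for them only; others in the source may bear on it.

In a functional assay on MCF7 cells (Homo sapiens) for antiproliferative activity, read by MTT assay, with a stated time of 24 h (on this read-out higher numbers stand for weaker inhibition and lower numbers for stronger inhibition), compound 1 `CCn1c(C(=O)N[C@@H](C)C(=O)OC)ccc1C(CC)(CC)c1ccc(OCS(=O)(=O)c2ccccc2)c(C)c1` gives 43700 nM. Its counterpart, compound 2 `CCn1c(C(=O)N[C@H](C)C(=O)OC)ccc1C(CC)(CC)c1ccc(OCS(=O)(=O)c2ccccc2)c(C)c1`, reaches only a limit, > 50000 nM. These two show an at least 1.1-fold higher number from compound 1 to compound 2 (0.05 log units; that floor lies within the scatter), a comparison resting on (the fact that compounds 1 and 2 differ only in the configuration as drawn). Compound 3 `CCn1c(C(=O)N[C@@H](CO)C(C)C)ccc1C(CC)(CC)c1ccc(OCS(=O)(=O)c2ccccc2)c(C)c1` gives 18800 nM, the lowest number among these compounds, and compound 1 is its nearest measured neighbour.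

The next compound, compound 4 `CCn1c(C(=O)N[C@H](CO)CCCO)ccc1C(CC)(CC)c1ccc(OCS(=O)(=O)c2ccccc2)c(C)c1`, keeps the shared core and changes only the group on an amide-type nitrogen: a group of 7 heavy atoms (5 carbon, 2 oxygen; no ring) in place of a group of 6 heavy atoms (5 carbon, 1 oxygen; no ring), on an amide-type nitrogen. The two measured steps that bear on it were made at this same place, where a 1-(hydroxymethyl)-2-methylpropyl group entered. They are a 2.3-fold lower number from compound 1 to compound 3 (0.37 log units; beyond the scatter) and an at least 2.6-fold lower number from compound 2 to compound 3 (0.42 log units; beyond the scatter), and both are modest in size. Within the data shown here, neither step tests the incoming group, so they indicate only how far a change at this nitrogen has moved the number so far.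

Since compound 3 already holds the lowest number, with 18800 nM, the more likely direction is upward. The expected change is a 1.5-fold higher number from compound 3 to compound 4 (0.17 log units; within the scatter), a modest weakening of similar size to the steps seen at this nitrogen. For compound 4 the estimated value in this assay is 28000 nM, with an expected range from 11000 nM to 60000 nM.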

Compound 4, half-maximal inhibitory concentration: 31400 nM
Beside the measured number, compound 4's estimate is 1.1-fold (0.05 log units) below it; low and high end bracket the measured number.
By their numbers in this assay, from the lowest: compounds 3, 4 and 1 (each within the scatter of the next, the first and the last beyond it). At a limit, above all of these: compound 2.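

In this assay, the swap at this amide-type nitrogen to the group with 7 heavy atoms, 2 hydrogen-bond donors and 2 hydrogen-bond acceptors gives a 1.7-fold higher number from compound 3 to compound 4 (0.22 log units; within the scatter), so the added donor and acceptor bring no change that stands clear of the scatter. The step of a 1.4-fold lower number from compound 1 to compound 4 (0.14 log units; within the scatter) is also within the scatter, which places compound 4 within reach of both compound 1 and compound 3, even though those two are separated by a step beyond the scatter; at this position, the new group therefore does not settle which of the two it resembles. Compound 2 gives only a limit, so an at least 1.5-fold lower number from compound 2 to compound 4 (0.20 log units; that floor lies within the scatter) is a floor and not a measured size, and it shows no more than that compound 4 gave a number where compound 2 did not: the limit of > 50000 nM in this assay, at which 1 of the 4 values shown sits.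

Open, as far as these compounds go, is whether a carboxylic acid or an amine at the end of the chain on this nitrogen, or a longer chain, would move the number beyond the scatter. Among these compounds, also open is how much the configuration at the chain carbon counts for the groups that carry hydroxyl, since the only pair differing in configuration alone, compounds 1 and 2, ends at a limit.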